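Bromo chain shortening, compound 3 to compound 4

A few compounds are considered here, and "the series" means these few. Any claim that something is new, unique, unknown or untested is made for them only; others in the source may bear on it.

Values so far in a functional assay on PC-3 cells (Homo sapiens) for inhibition, read by MTT assay, with a stated time of 48 h; a higher number here means a weaker inhibitor, a lower number a stronger inhibitor
compound 1 `COc1ccc(-c2coc3cc(OCCCCSC(=S)N4CCN(C(=O)OC(C)(C)C)CC4)ccc3c2=O)cc1` gives 4610 nM
compound 2 `CCN1CCN(C(=S)SCCCOc2ccc3c(=O)c(-c4ccc(OC)cc4)coc3c2)CC1` gives 7080 nM
compound 3 `COc1ccc(-c2coc3cc(OCCCCCBr)ccc3c2=O)cc1` gives 44800 nM

Compound 3 stands highest of the three numbers. Its nearest neighbour gives a 6.3-fold higher number from compound 2 to compound 3 (0.80 log units; beyond the scatter) as the gap, while compound 1 sits further off.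

The next structure is compound 4 `COc1ccc(-c2coc3cc(OCCBr)ccc3c2=O)cc1` and the change is bromo in place of 3-bromopropyl on a saturated chain carbon, two bonds along the chain from an oxygen on an aromatic ring so that 5-bromopentyl becomes 2-bromoethyl on the shared core.

Among the compounds with values here, no measured step changes chain length alone. Within the data shown here, the only measured step, a 6.3-fold higher number from compound 2 to compound 3 (0.80 log units; beyond the scatter) in this assay here, exchanges a much larger group for a bromo-ended chain, so it bears only loosely on this change. It gives no direction for shortening the chain. No step beyond the scatter is therefore expected, though the uncertainty remains wide. The expected step is a 1.1-fold lower number from compound 3 to compound 4 (0.05 log units; within the scatter) on this reasoning. For compound 4 the estimated value is 40000 nM with an expected range from 14000 nM to 100000 nM in this assay.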

Compound 4, half-maximal inhibitory concentration: 41900 nM
Compound 4: middle estimate off by 1.0-fold (0.02 log units), on the low side; low and high end bracket the measured number.
By their numbers in this assay, from the lowest: compounds 1 and 2 (each within the scatter of the next); then compounds 4 and 3 (each within the scatter of the next).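

In this assay, within the data shown here, the chain can be read on its own for the first time, and the step is a 1.1-fold lower number from compound 3 to compound 4 (0.03 log units; within the scatter). Shortening 5-bromopentyl to 2-bromoethyl on the shared core, with bromine kept at the chain end, therefore leaves no readable difference for this pair. No measurement on hand accounts for this result.

Still open, on these data alone, is whether chain length stays without consequence when the bromine is exchanged for another end group, such as an amine or a carboxylic acid, or when the chain runs longer than 5-bromopentyl. Also open, as far as these compounds go, is whether the larger ring-bearing end group of compound 2 responds to a change in chain length alone as the bromo end does.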